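The compounds below may be only part of what the source reports. "The series", "measured", "known", "first", "only" and "open" are said of these compounds alone.

The series shares one core; what varies is the group on the ring oxygen. Compound 1 `CC1CCCCC1Oc1cccc2ccc(N)nc12` gives 32 nM in an assay on cells with melanin-concentrating hormone receptor 1 (Homo sapiens) as the target, read by radioligand binding; on this read-out higher numbers stand for weaker inhibition and lower numbers for stronger inhibition. Within the data shown here, compound 2 `CCCC(C)Oc1cccc2ccc(N)nc12`, carrying a 1-methylbutyl group in that place, gives 105 nM in this assay, the second-highest of the three numbers measured so far: compound 1 sits at a lower number, beyond the scatter, while compound 3 `CC1CCCC(Oc2cccc3ccc(N)nc23)C1`, which gives 640 nM, sits at a higher number, also beyond the scatter.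

Compound 4 `CSCCOc1cccc2ccc(N)nc12` has not yet been measured. It differs from compound 2 in one place: 2-(methylsulfanyl)ethyl in place of 1-methylbutyl on an oxygen on an aromatic ring. Among the measured compounds shown here, no step between two measured compounds matches this change, so nothing in the measured set speaks to it directly. For the measured compounds named here, compound 2 is the only chain-bearing member measured; the other two carry rings, and their values stand on either side of it. The change is expected to move this assay towards a weaker number by a moderate step, with real uncertainty in both directions. Compound 4 is expected to come in at 300 nM, within 90 nM to 1000 nM. The step from compound 2 to compound 4 is then expected to be a 2.9-fold higher number from compound 2 to compound 4 (0.46 log units; beyond the scatter), though an outcome within the scatter of compound 2 would not surprise.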

Compound 4, half-maximal inhibitory concentration: > 2000 nM
Compound 4: no number, only a limit; the forecaster's own chance of this, stated with the estimate: 5%; middle value at least 6.6-fold (0.82 log units) from the limit.
By their numbers in this assay, from the lowest: compound 1; then compound 2; then compound 3. At a limit, above all of these: compound 4.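

In this assay the reading for compound 4 is a limit and not a number: the limit of > 2000 nM in this assay, at which 1 of the 4 values shown sits. Placing 2-(methylsulfanyl)ethyl in place of 1-methylbutyl on an oxygen on an aromatic ring gives an at least 19-fold higher number from compound 2 to compound 4 (1.27 log units; beyond the scatter), a large step that counts as a minimum. Among these compounds, this is the only step read between two compounds differing in one place, and it shows that an open chain at this position does not by itself preserve the values seen for compound 2, which the earlier compounds, differing from one another in more than one respect, could not show.

As far as these compounds go, the step changes the sulfur content, the branching and the chain length together, so it does not tell which of these goes with the result, and how far compound 4 lies past the limit also stays open. An unbranched butyl chain, a 2-methoxyethyl group or a 2-(dimethylamino)ethyl group on the same oxygen would each be needed to separate these contributions.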